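This account rests on a few compounds, and the source may have more. Where it says the series, first, only, none or still open, it means among the compounds named here.

Compound 1 `Cc1ccc(S(=O)(=O)N2C=CNC(=O)[C@H]2CC(=O)N[C@H](C)c2ccccc2)cc1` and compound 2 `Cc1ccc(S(=O)(=O)N2C=CNC(=O)[C@H]2CC(=O)NC2CCCCC2)cc1` share one core and differ only in the group on the amide nitrogen. In an in vitro functional assay on cells for antagonist activity at B1 bradykinin receptor (Homo sapiens), read by luminescence and calcium flux, with a stated time of 2 h (on this read-out higher numbers stand for weaker inhibition and lower numbers for stronger inhibition), compound 1 gives 836 nM, and compound 2 gives 990 nM; the step of a 1.2-fold higher number from compound 1 to compound 2 (0.07 log units; within the scatter) lies within the scatter, so compound 2 stands beside compound 1 without a real gap between them. Compound 3 `Cc1ccc(S(=O)(=O)N2C=CNC(=O)[C@H]2CC(=O)NC2CCC(C)CC2)cc1` differs from compound 2 by methyl in place of hydrogen on a saturated ring carbon. Within the data shown here, no measured step bears on this change; the only step seen, a 1.2-fold higher number from compound 1 to compound 2 (0.07 log units; within the scatter), concerns a different group. Compound 3 is therefore expected to show no step beyond the scatter, a 1.0-fold higher number from compound 2 to compound 3 (0.00 log units; within the scatter). Compound 3 is estimated at 1000 nM, with a range from 400 nM to 2500 nM.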

Compound 3, half-maximal inhibitory concentration: 314 nM
Compound 3: the middle estimate sits 3.2-fold (0.50 log units) above what was measured, and the stated range ends above it.
By their numbers in this assay, from the lowest: compound 3; then compounds 1 and 2 (each within the scatter of the next).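

In this assay a single methyl on a saturated ring carbon, three ring bonds from the ring atom that bears a large group, gives a 3.2-fold lower number from compound 2 to compound 3 (0.50 log units; beyond the scatter) and so moves the number beyond the scatter, which swapping 1-phenylethyl for cyclohexyl had not done. The 4-methylcyclohexyl group also stands apart from 1-phenylethyl, with a 2.7-fold lower number from compound 1 to compound 3 (0.43 log units; beyond the scatter) as the step. Nothing at hand explains why this methyl matters. Going by these compounds, whether an ethyl, a hydroxyl or a fluorine at this ring carbon would lower the number further remains open.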